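Swapping a selenocyanate ester chain for methylselanyl

The source may hold more compounds than are shown below. What is called first, only, known or untested is meant among the compounds shown, and "the series" means these compounds.

Measured compounds:
- compound 1, `COc1ccc(N(C)c2nc(C)nc3ccccc23)cc1C(=O)OCCCCC[Se]C#N`: 551 nM
- compound 2, `COc1ccc(N(C)c2nc(C)nc3ccccc23)cc1C(=O)OCC[Se]C#N`: 951 nM
- compound 3, `COc1ccc(N(C)c2nc(C)nc3ccccc23)cc1C(=O)OCCCCCC[Se]C#N`: 1990 nM

In a functional assay on HCT-116 cells (Homo sapiens) for inhibition, read by MTT assay, with a stated time of 48 h (a lower number here means a stronger inhibitor, a higher number a weaker inhibitor), compound 2 gives 951 nM, the second highest of the three numbers. Its nearest neighbour is compound 1, a 1.7-fold higher number from compound 1 to compound 2 (0.24 log units; within the scatter), and its furthest is compound 3, a 2.1-fold higher number from compound 2 to compound 3 (0.32 log units; beyond the scatter). Compound 1 and compound 3 differ by a 3.6-fold higher number from compound 1 to compound 3 (0.56 log units; beyond the scatter).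

Compound 4, `COc1ccc(N(C)c2nc(C)nc3ccccc23)cc1[Se]C`, differs from compound 2 by a group of 2 heavy atoms (1 carbon, 1 selenium; no ring) in place of a group of 8 heavy atoms (4 carbon, 1 nitrogen, 2 oxygen, 1 selenium; no ring), on an aromatic carbon. Among the measured compounds shown here, the three measured steps all concern the length of the saturated chain between the ester and the selenium; none of them removes the ester or the nitrile on selenium, so no step bears directly on this change. Those chain-length steps were modest at most. For the measured compounds named here, with no direct precedent, a weaker result is expected but held loosely: compound 4 is estimated at a 1.9-fold higher number from compound 2 to compound 4 (0.28 log units; within the scatter) in this assay, placing it near 1800 nM, with a plausible range from 300 nM to 10000 nM.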

Compound 4, half-maximal inhibitory concentration: 28 nM
For compound 4 the middle estimate is 64-fold (1.81 log units) above the measured one; the measured number lies below the stated range.
By their numbers in this assay, from the lowest: compound 4; then compounds 1 and 2 (each within the scatter of the next); then compound 3.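

The earlier compounds shown here changed only the length of the saturated chain, and those steps were modest at most. Replacing the whole ester chain on the aromatic carbon ortho to a methoxy group has a much larger effect in this assay, with a 34-fold lower number from compound 2 to compound 4 (1.53 log units; beyond the scatter), so in this comparison the small methylselanyl group is enough at this position and the ester, chain and nitrile are not needed for a low number. Nothing here explains why this swap gives such a large step.

On these data alone, the ester, the chain and the nitrile all leave in one step, so their separate contributions remain unknown. As far as these compounds go, it is also open whether a methylthio group or an ethylselanyl group at this position would give a number close to that of methylselanyl.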